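The source may hold more compounds than are shown below. What is called first, only, known or untested is meant among the compounds shown, and "the series" means these compounds.

Compound 1 `COc1cc(OC)c2cc(-c3ccccc3)c(O)nc2c1`: 10000 nM
Compound 2 `COc1ccc(-c2cc3c(OC)cc(OC)cc3n(CC(=O)OCc3ccccc3)c2=O)cc1`: 10000 nM

These two compounds were tested in a functional assay on U-87MG ATCC cells for cytotoxicity against U-87 MG (Homo sapiens), read by colorimetric assay and MTT assay; on this read-out higher numbers stand for weaker inhibition and lower numbers for stronger inhibition. Compound 2, at 10000 nM, stands level with compound 1, and nothing separates them beyond the usual scatter of repeated measurements. The next compound to follow is compound 3 `COc1ccc(-c2cc3c(OC)cc(OC)cc3n(CCC(=O)OCc3ccccc3)c2=O)cc1`, which has not yet been measured. It differs from compound 2 in one place, with (benzyloxycarbonyl)methyl in place of benzyloxycarbonyl on a saturated chain carbon bound to an aromatic nitrogen. Within the data shown here, no measured pair of compounds differs in just one place, so the data offer no direct guide to this change. The expectation in this assay therefore rests on compound 2 at 10000 nM, and no shift beyond the scatter is expected in either direction. The expected change is no change at the digits printed from compound 2 to compound 3 (within the scatter). The estimate for compound 3 is 10000 nM, with an expected range of 4000 nM to 20000 nM.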

Compound 3, half-maximal inhibitory concentration: 10000 nM
Estimate against measurement, compound 3: no gap at the digits printed; low and high end bracket the measured number.
By their numbers in this assay, from the lowest: compounds 1, 2 and 3 (each within the scatter of the next).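

In this assay, replacing benzyloxycarbonyl with (benzyloxycarbonyl)methyl on a saturated chain carbon bound to an aromatic nitrogen gives no change at the digits printed from compound 2 to compound 3 (within the scatter). Among these compounds, this is the first comparison here of two compounds that differ in one place, and it shows that one more carbon in the entering group, with the same aromatic ring and the same counts of hydrogen-bond donors and acceptors, leaves the number unmoved. No measurement shown explains why the number holds.

As far as these compounds go, whether a different kind of group at this place, such as a free carboxylic acid in place of the benzyl ester, an amine or a still longer chain, would shift the number remains open. A single step also cannot show whether any change at this place could lower the number.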